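The source may hold more compounds than are shown below. What is called first, only, known or untested is meant among the compounds shown, and "the series" means these compounds.

Compound 1 `[O-][n+]1ccc2c(c1)ncn2[C@H]1C[C@H](O)[C@@H](CO)O1` gives 0%; compound 2 `Clc1[nH]ccc2ncnc1-2` gives 6%; compound 3 `OC[C@H]1OC(n2cnc3c(SCc4ccccc4)nccc32)[C@H](O)[C@@H]1O` gives 30%.

These three values come from a functional assay (Homo sapiens) for inhibition of Nucleic Acid, tested at 100 uM; a higher number here means more inhibition at the concentration tested (going by the name of the read-out), a lower number less inhibition. Compound 2 holds the second highest of the three numbers. Its nearest neighbour is compound 1, whose value sits within the usual scatter, so the two cannot be told apart. Compound 3 lies furthest away, with a value beyond the scatter, so compound 3 shows clearly more inhibition than compound 2. Compound 4 `CN(C)c1[nH]ccc2ncnc1-2` has not yet been measured. It differs from compound 2 in one place: dimethylamino in place of chloro on an aromatic carbon. Among the compounds with values here, no measured pair shows this kind of exchange, so there is no step to lean on. In this assay a step from compound 2 to compound 4 of no more than the scatter is expected, in no firm direction. The value of compound 4 in this assay is estimated at 10%, between 0% and 30%, which means an expected step of a number 4 percentage points higher from compound 2 to compound 4 (within the scatter).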

Compound 4, a percentage reported as inhibition, at one concentration (the size of the read-out at that concentration, not a potency): 8%
Compound 4: middle estimate off by 2 percentage points, on the high side; the measured number falls inside the stated range.
By their numbers in this assay, from the lowest: compounds 1, 2 and 4 (each within the scatter of the next); then compound 3.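

Within the data shown here, this is the first direct reading at this position: in this assay, placing dimethylamino instead of chloro on the aromatic carbon next to the ring nitrogen gives a number 2 percentage points higher from compound 2 to compound 4 (within the scatter), so the two compounds cannot be told apart. Here, then, the exchange leaves no readable mark on the result, although the two groups differ in heavy atoms and hydrogen-bond acceptors. Nothing available offers an explanation for this result. From the compounds shown here alone, whether a primary amine, a methoxy group or a longer chain at this position would give a clearly different reading remains open.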